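From fluoro to a thiazolyl group: working notes

The compounds below may be only part of what the source reports. "The series", "measured", "known", "first", "only" and "open" are said of these compounds alone.

Measured in an ADME assay on Raji cells (Homo sapiens) for cytotoxicity, read by luminescence, with a stated time of 72 h (a lower number here means that less compound is needed, a higher number that more compound is needed for the effect), each entry being a limit of the assay:
compound 1 `CCOC(=O)c1c(-c2cccc(F)c2)[nH]c2cc(OC)ccc2c1=O`: > 21500 nM
compound 2 `CCOC(=O)c1c(-c2cccc(C(C)=O)c2)[nH]c2cc(OC)ccc2c1=O`: > 21500 nM
compound 3 `CCOC(=O)c1c(-c2cccc(F)c2)[nH]c2cc(OC)c(F)cc2c1=O`: > 21500 nM

Compound 3 gives > 21500 nM, which is a limit and not a number. The two other compounds also stand at limits, so the series offers only (the limit of > 21500 nM in this assay, at which 3 of the 3 values shown sit).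

Compound 4 `CCOC(=O)c1c(-c2cccc(-c3nc(C)c(C)s3)c2)[nH]c2cc(OC)c(F)cc2c1=O` carries 4,5-dimethyl-1,3-thiazol-2-yl in place of fluoro on an aromatic carbon, meta to a large group: 4,5-dimethyl-1,3-thiazol-2-yl in place of fluoro on an aromatic carbon.

The closest measured change is a step that the two limits leave unreadable from compound 1 to compound 2, which also replaces fluoro on an aromatic carbon, here with acetyl. The other measured change is a step that the two limits leave unreadable from compound 1 to compound 3, and compound 3 already carries that fluoro. For the measured compounds named here, neither step has a readable size, and no measured compound holds the entering group. The estimate is therefore an at least 1.0-fold lower number from compound 3 to compound 4 (0.03 log units; that floor lies within the scatter), with any real move expected toward less compound needed. Compound 4 may well report only a limit again. For compound 4 the estimated value is 20000 nM, with an expected range from 6000 nM to 40000 nM.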

Compound 4, half-maximal effective concentration: > 21500 nM
Compound 4 was reported as a limit; the forecaster's own chance of this, stated with the estimate: 70%; at least 1.0-fold (0.03 log units) between middle value and limit.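

Compound 3 and compound 4 both stand at a limit of the assay, so no size can be read for the step between them: the limit of > 21500 nM in this assay, at which 4 of the 4 values shown sit.

The compounds shown leave open whether any change on the shared core moves the read-out off this limit, and how large such a move would be.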